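A few compounds are considered here, and "the series" means these few. Any claim that something is new, unique, unknown or untested is made for them only; others in the source may bear on it.

In a functional assay on MCF7 cells (Homo sapiens) for antiproliferative activity, read by sulforhodamine B assay, with a stated time of 72 h (on this read-out higher numbers stand for weaker inhibition and lower numbers for stronger inhibition), compound 1 `COc1ccc(/C=C2\CCC=CC2=O)cc1` gives 2570 nM, compound 3 `COc1cc(/C=C2\CCC=CC2=O)cc(OC)c1O` gives 2180 nM, and compound 2 `O=C1C=CCC/C1=C\c1ccc(OC(F)(F)F)cc1` gives 1040 nM, the lowest of the three numbers. Compound 4 `O=C1C=CCC/C1=C\c1ccc(-c2ccccc2)cc1` has phenyl in place of trifluoromethoxy on an aromatic carbon of compound 2: phenyl in place of trifluoromethoxy on an aromatic carbon. Among the compounds with values here, only one measured step touches this substituent, trifluoromethyl in place of methyl on an oxygen on an aromatic ring, and it is modest: a 2.5-fold lower number from compound 1 to compound 2 (0.39 log units; beyond the scatter). Within the data shown here, no measured step shows what an entering ring does, so no shift beyond the scatter is expected in this assay, in either direction. The expected step is a 1.2-fold higher number from compound 2 to compound 4 (0.06 log units; within the scatter). For compound 4 the estimated value is 1200 nM, with an expected range of 400 nM to 3500 nM.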

Compound 4, half-maximal inhibitory concentration: 4970 nM
The estimate for compound 4 lay 4.1-fold (0.62 log units) below the measured number; the whole stated range lies below it.
By their numbers in this assay, from the lowest: compound 2; then compounds 3, 1 and 4 (each within the scatter of the next, the first and the last beyond it).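

In this assay, within the data shown here, phenyl in place of trifluoromethoxy on the aromatic carbon gives a 4.8-fold higher number from compound 2 to compound 4 (0.68 log units; beyond the scatter) and is the first measured step at this position to an entering ring. Against the methoxy compound, phenyl gives a 1.9-fold higher number from compound 1 to compound 4 (0.29 log units; within the scatter) so compound 4 and compound 1 cannot be told apart here. The lead of compound 2 therefore belongs to trifluoromethoxy and does not carry over to phenyl.

From the compounds shown here alone, whether an amine, a carboxylic acid or a longer chain at this position would stand with compound 2 or with compound 4 remains open. No measurement at hand accounts for the step from trifluoromethoxy to phenyl.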